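Swapping a Ring for a Plain Chain on Compound 2

The source may hold more compounds than are shown below. What is called first, only, known or untested is meant among the compounds shown, and "the series" means these compounds.

Of the compounds shown here, three have been measured in a functional assay on a cell-free system (plasma, Homo sapiens), with a stated time of 3 min; a lower number here means a stronger inhibitor, a higher number a weaker inhibitor. Compound 1 `CCCC[C@@H](O)C(=O)N1N=CC[C@H]1C(=O)NCc1cc(Cl)ccc1-n1cnnn1` gives 610 nM. Compound 2 `CC1(C[C@@H](O)C(=O)N2C[C@H]3C[C@H]3[C@H]2C(=O)NCc2cc(Cl)ccc2-n2cnnn2)CC1`, with a different core and a different side group, gives 500 nM, the lowest of the three numbers; compound 1 sits within the scatter of it, while compound 3 `CC(C)(C)[C@@H](O)C(=O)N1N=CC[C@H]1C(=O)NCc1cc(Cl)ccc1-n1cnnn1`, at 1400 nM, lies beyond. Going by the values given here, the one step that changes a single place, a 2.3-fold higher number from compound 1 to compound 3 (0.36 log units; beyond the scatter), shows that tert-butyl in place of butyl raised the number modestly.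

Compound 4 `CCCC[C@@H](O)C(=O)N1C[C@H]2C[C@H]2[C@H]1C(=O)NCc1cc(Cl)ccc1-n1cnnn1` keeps the core of compound 2 and alters the side group: propyl in place of 1-methylcyclopropyl on a saturated chain carbon, two bonds along the chain from a carbonyl carbon and an oxygen on a saturated carbon. Among the compounds with values here, no measured pair shows exactly this change. The step from compound 1 to compound 3 went toward a bulkier group and upward; here a group with a three-membered ring gives way to propyl, so a rise seems unlikely. Compound 1 and compound 2 also sit within the scatter of each other despite differing in both core and side group. Compound 4 is therefore expected to give about 550 nM, with a range of 300 nM to 1100 nM. The expected step, a 1.1-fold higher number from compound 2 to compound 4 (0.04 log units; within the scatter), stays within the scatter.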

Compound 4, half-maximal inhibitory concentration: 750 nM
Compound 4: middle estimate off by 1.4-fold (0.13 log units), on the low side; measured number inside the range.
By their numbers in this assay, from the lowest: compounds 2, 1, 4 and 3 (each within the scatter of the next, the first and the last beyond it).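

In this assay, putting propyl in place of 1-methylcyclopropyl, on a saturated chain carbon two bonds along the chain from a carbonyl carbon and an oxygen on a saturated carbon, gives a 1.5-fold higher number from compound 2 to compound 4 (0.18 log units; within the scatter), so at this place on the core of compound 2 the three-membered ring can go without a change that stands out from the scatter. The earlier step, a 2.3-fold higher number from compound 1 to compound 3 (0.36 log units; beyond the scatter), was a change on another core and went beyond the scatter, whereas this one does not. No measurement at hand bears on what lies behind this result.

Going by these compounds, it remains open whether a longer chain, an amine or a carboxylic acid at this place would keep the number in the same range. On these data alone, whether 1-methylcyclopropyl would behave the same way on the core of compound 1 is also open.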